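Swapping methoxy for carboxy in a urea series

A few compounds are considered here, and "the series" means these few. Any claim that something is new, unique, unknown or untested is made for them only; others in the source may bear on it.

Three ureas share one core and differ only in the aryl group on a saturated ring carbon. In an assay on microsomes for inhibition of acyl-CoA:cholesterol acyltransferase (Oryctolagus cuniculus) (a lower number here means a stronger inhibitor, a higher number a weaker inhibitor), compound 1 `CC(C)c1cccc(C(C)C)c1NC(=O)NCC1(c2ccc(CC(C)(C)C)cc2)CCCC1` gives 159 nM. Compound 2 `COc1ccc(C2(CNC(=O)Nc3c(C(C)C)cccc3C(C)C)CCCC2)cc1` gives 31 nM in this assay, and compound 3 `CC(C)c1cccc(C(C)C)c1NC(=O)NCC1(c2cccc(N(C)C)c2)CCCC1` gives 33 nM. Compound 2 has the lowest number of the three, yet its gap to compound 3 is within the scatter: a 1.1-fold higher number from compound 2 to compound 3 (0.03 log units; within the scatter). Its gap to compound 1 is larger, a 5.1-fold lower number from compound 1 to compound 2 (0.71 log units; beyond the scatter), and likewise a 4.8-fold lower number from compound 1 to compound 3 (0.68 log units; beyond the scatter).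

Compound 4 `CC(C)c1cccc(C(C)C)c1NC(=O)NCC1(c2ccc(C(=O)O)cc2)CCCC1` has not yet been measured. It differs from compound 2 in one place: carboxy in place of methoxy on an aromatic carbon. Among the measured compounds shown here, only the step from compound 1 to compound 2 changes the group on that same aromatic carbon, and it moved the number by a modest amount. For the measured compounds named here, no measured step introduces a carboxy group or any group carrying a hydrogen-bond donor at that place, so the measured steps give little direct guidance. Given that, a step toward a higher number is expected for compound 4, a 13-fold higher number from compound 2 to compound 4 (1.11 log units; beyond the scatter), with wide uncertainty. The estimate for compound 4 in this assay is 400 nM, ranging from 50 nM to 4000 nM.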

Compound 4, half-maximal inhibitory concentration: 3100 nM
Estimate against measurement, compound 4: 7.8-fold (0.89 log units) below, within the range that was stated.
By their numbers in this assay, from the lowest: compounds 2 and 3 (each within the scatter of the next); then compound 1; then compound 4.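

In this assay, among the compounds shown here, this aromatic carbon, para to a large group, had so far carried only neopentyl and methoxy, and carboxy is the first group there with a hydrogen-bond donor; the swap from methoxy gives a 100-fold higher number from compound 2 to compound 4 (2.00 log units; beyond the scatter) and is far larger than the earlier change at this carbon. For the compounds shown here, the carboxy compound also falls well behind the other two, with a 19-fold higher number from compound 1 to compound 4 (1.29 log units; beyond the scatter) and a 94-fold higher number from compound 3 to compound 4 (1.97 log units; beyond the scatter) in a step that also moves the ring substituent to a different place, so it is the only compound here that breaks from the narrow spread of the earlier three. Nothing shown here explains why this one change costs so much.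

The compounds shown do not tell whether the loss belongs to carboxy itself or would also appear with a hydroxy group, a primary amide or a methyl ester on the same carbon. They also leave open whether a carboxylic acid set further out on a longer chain, such as a carboxymethyl group, would give a number closer to that of the methoxy compound.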